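The source may report more compounds than this note shows. Statements on the series, on what has been measured and on what is new or still open speak of the compounds shown alone.

Compound 1 `Cc1n[nH]c(-c2ccccc2NCC2=NCCN2)n1`: < 5020 nM in an in vitro functional assay on cells (Fibroblast) for agonist activity at Alpha-1D adrenergic receptor (Homo sapiens); a lower number here means that less compound is needed, a higher number that more compound is needed for the effect
Compound 2 `Cc1nc(-c2ccccc2NCC2=NCCN2)n(C)n1`: < 5020 nM in this assay

Compound 1 stands only at a limit: in this assay compound 1 gives < 5020 nM, which is a limit of the assay and not a measured number. The same holds for compound 2, whose result of < 5020 nM is likewise a limit. Among the measured compounds shown here, the one measured step, a step that the two limits leave unreadable from compound 1 to compound 2, therefore cannot be read in size or direction, and all the two results share is the limit of < 5020 nM in this assay, at which 2 of the 2 values shown sit. Compound 3 `Cn1cc(-c2ccccc2NCC2=NCCN2)cn1` differs from compound 1 by 1-methyl-1H-pyrazol-4-yl in place of 3-methyl-1H-1,2,4-triazol-5-yl on an aromatic carbon. For the measured compounds named here, no measured step here follows a swap of one five-membered ring for another, so the size of the step in this assay remains open in either direction. Compound 3 is expected to land near 1500 nM, in a range from 150 nM to 8000 nM. That expectation amounts to an estimated step that the limit leaves unreadable from compound 1 to compound 3.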

Compound 3, half-maximal effective concentration: < 100000 nM
Compound 3: no number, only a limit; the forecaster's own chance of this, stated with the estimate: 45%; the middle value is on the limit's open side.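

In this assay compound 3 gives < 100000 nM, which is a limit and not a measured number. Among the compounds shown here, compound 1 and compound 3 both stand only at limits, and no step between them can be read. The compounds shown leave open whether 1-methyl-1H-pyrazol-4-yl in place of 3-methyl-1H-1,2,4-triazol-5-yl changes the concentration needed, and in which direction.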